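The source may hold more compounds than are shown below. What is called first, only, known or untested is meant among the compounds shown, and "the series" means these compounds.

Three measured compounds frame this step. Compound 1 `CN(Cc1cc(C(F)(F)F)cc(C(F)(F)F)c1)C(=O)c1c(-c2ccccc2)c2cccnc2c(=O)n1C` in an assay on IM-9 cells for binding affinity to Substance-P receptor (Homo sapiens) (a higher number here means a weaker inhibitor, a lower number a stronger inhibitor), gives 0.25 nM. Compound 2 `COc1ccccc1CN(C)Cc1c(-c2ccccc2)c2cc(C)c(C)cc2c(=O)n1C` in this assay gives 800 nM. Compound 3 `Cc1cc2c(-c3ccccc3)c(NC(=O)N(C)Cc3ccccc3)n(C)c(=O)c2cc1C` in this assay gives 16 nM. Among these three numbers compound 3 stands second highest: compound 2 gives a higher number and compound 1 a lower one, and both of those gaps lie beyond the usual scatter of repeated measurements. Compound 4 `CCN(Cc1ccccc1)C(=O)Nc1c(-c2ccccc2)c2cc(C)c(C)cc2c(=O)n1C` differs from compound 3 in one place: methyl in place of hydrogen on a saturated chain carbon bound to an amide-type nitrogen. Among the compounds with values here, no pair of measured compounds shows what this change does on its own, so the measured set gives no direct size for it. With only a methyl entering on a saturated chain carbon bound to an amide-type nitrogen, the change is expected to be modest, a 1.6-fold higher number from compound 3 to compound 4 (0.19 log units; within the scatter), quite possibly not beyond the scatter, with a slight lean toward a higher number. Compound 4 is therefore estimated at 25 nM, within a range from 8 nM to 80 nM.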

Compound 4, half-maximal inhibitory concentration: 66 nM
Compound 4: middle estimate off by 2.6-fold (0.42 log units), on the low side; the range from low to high includes it.
By their numbers in this assay, from the lowest: compound 1; then compound 3; then compound 4; then compound 2.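

In this assay, the change from benzyl(methyl)amino to benzyl(ethyl)amino gives a 4.1-fold higher number from compound 3 to compound 4 (0.62 log units; beyond the scatter), so one added methyl on a saturated chain carbon bound to an amide-type nitrogen has a readable effect that lies beyond the scatter. Within the data shown here, this is the first direct measure of a single change in the set, and it shows that this position is sensitive to even this small extension, with the methyl form the stronger inhibitor of the pair. Nothing in the available evidence accounts for the size of this step. Going by these compounds, whether a longer chain such as propyl, or a hydroxyethyl chain, would raise the number further remains open. Also open, on these data alone, is whether the same methyl to ethyl change would carry the same cost on the core of compound 1.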